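Compound 3 and a swap on its aryl group

The source may report more compounds than this note shows. Statements on the series, on what has been measured and on what is new or still open speak of the compounds shown alone.

- compound 1 (`CCN1CCN(c2nc(C)nc3c2nc(-c2ccccc2Cl)n3CCOC)CC1`) at 53%
- compound 2 (`CCN1CCN(c2nc(C)nc3c2nc(-c2ccccc2Cl)n3CC2CCOCC2)CC1`) at 80%
- compound 3 (`COc1ccccc1-c1nc2c(N3CCN(C)CC3)nc(C)nc2n1C1CCOCC1`) at 35%

In an ADME assay (liver) for metabolic stability, with Liver microsome (Rattus norvegicus) as the target, read by LC-MS, using microsomes, with a stated time of 30 min, tested at 4 uM (on this read-out higher numbers stand for a more stable compound and lower numbers for a less stable compound), compound 3 stands lowest of the three (35%), under compound 1 (53%) and further under compound 2 (80%), both gaps beyond the scatter. Compound 4 (`Cc1nc(N2CCN(C)CC2)c2nc(-c3ccccc3C3CC3)n(C3CCOCC3)c2n1`) carries cyclopropyl in place of methoxy on an aromatic carbon, the change from 2-methoxyphenyl to 2-cyclopropylphenyl. Among the compounds with values here, the only measured step (a number 27 percentage points higher from compound 1 to compound 2 (beyond the scatter)) puts oxan-4-yl in place of methoxymethyl on a saturated chain carbon bound to an aromatic nitrogen, which is a different change at a different place. It shows that one change can move this assay well beyond the scatter, but it gives no direction here. Within the data shown here, no measured pair exchanges methoxy for cyclopropyl, so the expected step (a number 3 percentage points higher from compound 3 to compound 4 (within the scatter)) stays within the scatter, though with wide uncertainty. For compound 4 the estimated value is 38% with an expected range from 18% to 60% around it.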

Compound 4, percent of the compound remaining: 67%
Compound 4: middle estimate off by 29 percentage points, on the low side; measured number outside the range, above it.
By their numbers in this assay, from the lowest: compound 3; then compound 1; then compound 4; then compound 2.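

In this assay, putting cyclopropyl in place of methoxy on an aromatic carbon of a six-membered aromatic ring of carbon only, ortho to a large group, gives a number 32 percentage points higher from compound 3 to compound 4 (beyond the scatter). The earlier step had shown a single change moving this read-out only on the saturated chain carbon bound to an aromatic nitrogen, whereas this one shows that the group on the aryl ring can move it as well, here upward. No measurement at hand bears on why the number rises.

On these data alone, it remains open whether the rise is particular to cyclopropyl or would also come with another group at this place, such as ethyl, isopropyl or trifluoromethyl. Also open, as far as these compounds go, is whether cyclopropyl in place of the chlorine of compound 1 and compound 2 would raise their numbers too.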